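Removing a Methoxy Group from Compound 3

The source may hold more compounds than are shown below. What is called first, only, known or untested is meant among the compounds shown, and "the series" means these compounds.

compound 1 `COc1cc(/C=C/C(=O)/C=C/c2ccccc2)ccc1OCc1cn(CCCCOc2cc(=O)oc3ccccc23)nn1`: 36%
compound 2 `COc1ccccc1/C=C/C(=O)/C=C/c1ccc(OCc2cn(CCCCOc3cc(=O)oc4ccccc34)nn2)c(OC)c1`: 40%
compound 3 `COc1ccc(/C=C/C(=O)/C=C/c2ccc(OCc3cn(CCCOc4cc(=O)oc5ccccc45)nn3)c(OC)c2)cc1OC`: 73%

The three values above come from a functional assay on THP-1 cells (Homo sapiens) for inhibition, read by sulforhodamine B assay, with a stated time of 48 h, tested at 50 uM; a lower number here means less inhibition of growth, a higher number more inhibition of growth at the concentration tested. Compound 3 stands highest; the difference between its core and that of compound 2 is not broken down here. The change hydrogen in place of methoxy on an aromatic carbon gives a number 4 percentage points lower from compound 2 to compound 1 (within the scatter). Compound 4 `COc1ccc(/C=C/C(=O)/C=C/c2ccc(OCc3cn(CCCOc4cc(=O)oc5ccccc45)nn3)c(OC)c2)cc1` carries the same kind of change, (hydrogen in place of methoxy on an aromatic carbon), but at a different place: ortho to a methoxy group and meta to a large group rather than ortho to a large group. Because the earlier step was a number 4 percentage points lower from compound 2 to compound 1 (within the scatter), a small step is the nearest guide, yet compounds 1 and 2 sit far below compound 3 with its 73%, so some loss is expected. Compound 4 is estimated at 58%, a step of a number 15 percentage points lower from compound 3 to compound 4 (beyond the scatter), within 35% to 78%.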

Compound 4, percent growth inhibition at one concentration: 56%
The estimate for compound 4 lay 2 percentage points above the measured number; the range from low to high includes it.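

In this assay, the change from 3,4-dimethoxyphenyl to 4-methoxyphenyl gives a number 17 percentage points lower from compound 3 to compound 4 (beyond the scatter). Set beside the earlier step, the loss of a methoxy group carries from one core to the other without a difference that can be told from the scatter: the same change on two cores in this assay, a number 4 percentage points lower (within the scatter) from compound 2 to compound 1 and a number 17 percentage points lower (beyond the scatter) from compound 3 to compound 4, 13 percentage points apart, within the scatter of two such steps. For the compounds shown here, this rests on only two pairs, with the change at a different place in each, so it does not show that the step would keep its size on a further core, or that the place makes no difference.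

The compounds shown leave open how a hydroxy group, a fluorine or an amine would read in place of that methoxy group. They also leave open whether the remaining methoxy group on that ring matters.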